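Hydroxy for Methyl on a Core Without Measured Inhibition

A few compounds are considered here, and "the series" means these few. Any claim that something is new, unique, unknown or untested is made for them only; others in the source may bear on it.

compound 1 `COC(=O)CC/C(C)=C/Cc1c(OC)c(C)c2c(c1OCC#CCN1CCN(c3ccc(C)cc3)CC1)C(=O)OC2` — > 50000 nM
compound 2 `COC(=O)CC/C(C)=C/Cc1c(OC)c(C)c2c(c1OCC#CCN1CCC(C(=O)OC)CC1)C(=O)OC2` — > 50000 nM

In a functional assay on HT-29 cells (Homo sapiens) for inhibition, read by sulforhodamine B assay (on this read-out lower numbers stand for stronger inhibition and higher numbers for weaker inhibition), compound 1 gives > 50000 nM, which is a limit of the assay and not a number. Compound 2 gives > 50000 nM in this assay, also a limit. Both values sit at the limit of > 50000 nM in this assay, at which 2 of the 2 values shown sit, so compound 1 cannot be placed above or below compound 2. Compound 3 `COC(=O)CC/C(C)=C/Cc1c(OC)c(C)c2c(c1OCC#CCN1CCN(c3ccc(O)cc3)CC1)C(=O)OC2` differs from compound 1 by hydroxy in place of methyl on an aromatic carbon. Among the measured compounds shown here, no measured pair shows this change in this assay. I expect the step that the limit leaves unreadable from compound 1 to compound 3 to be none beyond the scatter, because compound 1 and compound 2 both sit at the limit of > 50000 nM in this assay, at which 2 of the 2 values shown sit. Compound 3 is therefore expected at 60000 nM, within 20000 nM to 200000 nM, most likely again only a limit.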

Compound 3, half-maximal inhibitory concentration: > 50000 nM
Compound 3 ended at the assay's limit; the forecaster's own chance of this, stated with the estimate: 80%; the middle value lies beyond the limit too.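

In this assay, among the compounds shown here, compound 1 and compound 3 both end at a limit of the assay, so no step between them can be read: the limit of > 50000 nM in this assay, at which 3 of the 3 values shown sit.

The compounds shown leave open how strongly any of them inhibits, and whether hydroxy in place of methyl changes inhibition at all.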